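This account rests on a few compounds, and the source may have more. Where it says the series, first, only, none or still open, it means among the compounds named here.

Measured so far in an ADME assay on MT4 cells (Homo sapiens) for cytotoxicity, read by MTT assay; a higher number here means that more compound is tolerated, a lower number that less compound is tolerated:
compound 1 `Cc1ccc(-n2ccnc2SCC(=O)Nc2ccc(C)cc2Br)cc1` gives 80800 nM
compound 2 `Cc1ccc(NC(=O)CSc2nccn2-c2ccc(Cl)cc2)c(Br)c1` gives 221000 nM
compound 3 `COc1ccc(-n2ccnc2SCC(=O)Nc2ccc(C)cc2Br)cc1` gives 25800 nM

Compound 1 stands second highest of these three. Compound 4 `Cc1ccc(-n2ccnc2SCC(=O)Nc2ccccc2Br)cc1` differs from it by hydrogen in place of methyl on an aromatic carbon in the 2-bromo-4-methylphenyl group, with hydrogen in place of methyl on an aromatic carbon. For the measured compounds named here, all three measured compounds keep that group, so no measured step tests this change directly. The nearest evidence is methyl replaced elsewhere on an aromatic carbon, where a 2.7-fold higher number from compound 1 to compound 2 (0.44 log units; beyond the scatter) and a 3.1-fold lower number from compound 1 to compound 3 (0.50 log units; beyond the scatter) run in opposite directions. No step beyond the scatter is therefore expected, and the estimated step is a 1.2-fold lower number from compound 1 to compound 4 (0.06 log units; within the scatter) in this assay overall. For compound 4 the estimated value is 70000 nM with an expected range from 25000 nM to 200000 nM as its upper end.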

Compound 4, half-maximal cytotoxic concentration: 39300 nM
Estimate against measurement, compound 4: 1.8-fold (0.25 log units) above; measured number inside the range.
By their numbers in this assay, from the lowest: compounds 3 and 4 (each within the scatter of the next); then compound 1; then compound 2.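

In this assay, for the compounds shown here, hydrogen in place of methyl on the 2-bromo-4-methylphenyl group gives a 2.1-fold lower number from compound 1 to compound 4 (0.31 log units; beyond the scatter), so this position, which the earlier compounds all held unchanged, does bear on the number. Less compound is tolerated without the methyl, though the step is modest. Nothing measured here accounts for this step. The compounds shown leave open how an amine or a carboxylic acid at this position would read. They also leave open whether removing this methyl gives a similar step when the chloro of compound 2 or the methoxy of compound 3 is present.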